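Methyl added to the benzyl ether of compound 2

The source may hold more compounds than are shown below. What is called first, only, known or untested is meant among the compounds shown, and "the series" means these compounds.

Going by the values given here, in a functional assay on MCF7 cells (Homo sapiens) for inhibition, read by sulforhodamine B assay, with a stated time of 48 h (a lower number here means a stronger inhibitor, a higher number a weaker inhibitor), compound 2 (`COc1ccc(C(OCc2ccccc2)c2cccc3ccccc23)c(OC)c1OC`) gives 14100 nM as the only number. Compound 1 (`COc1ccc(C(O)(Cc2ccc(C)cc2)c2cccc3ccccc23)c(OC)c1OC`) stands at > 20000 nM as a limit. Compound 3 (`CCOC(=O)C(C)C(O)(c1ccc(OC)c(OC)c1OC)c1cccc2ccccc12`) stands at > 20000 nM as a limit too. Compound 4 (`COc1ccc(C(OCc2ccc(C)cc2)c2cccc3ccccc23)c(OC)c1OC`) carries methyl in place of hydrogen on an aromatic carbon, para to a large group, turning benzyloxy into (4-methylbenzyl)oxy. Among the compounds with values here, the only measured step is a step that the two limits leave unreadable from compound 1 to compound 3 and offers no size to carry over, while the limit of > 20000 nM in this assay, at which 2 of the 3 values shown sit, bounds what can be read. No step beyond the scatter is therefore expected in this assay, in either direction. The estimated step is a 1.0-fold lower number from compound 2 to compound 4 (0.00 log units; within the scatter) and stays within the scatter. Compound 4 is estimated at 14000 nM within a range from 7000 nM to 25000 nM as expected here.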

Compound 4, half-maximal inhibitory concentration: 10700 nM
Compound 4: middle estimate off by 1.3-fold (0.12 log units), on the high side; the range from low to high includes it.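

Going by these compounds alone, the first readable step in this assay is a 1.3-fold lower number from compound 2 to compound 4 (0.12 log units; within the scatter). At this place on the ring, para to a large group, (4-methylbenzyl)oxy and benzyloxy therefore read alike, and a single added methyl does not take the ether out of measurable range. This says nothing about larger groups at the same place.

From the compounds shown here alone, the step between compound 1 and compound 3 cannot be read: the limit of > 20000 nM in this assay, at which 2 of the 4 values shown sit. It remains open whether an amine or a carboxylic acid in place of that methyl, or a longer chain in place of the benzyl ether, would move the number beyond the scatter.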